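Replacing a Bromophenyl at the Limit with a Methoxyphenyl

This account rests on a few compounds, and the source may have more. Where it says the series, first, only, none or still open, it means among the compounds named here.

Measured in a functional assay on SW480 cells (Homo sapiens) for cytotoxicity, read by MTT assay, with a stated time of 48 h; a higher number here means a weaker inhibitor, a lower number a stronger inhibitor:
Compound 1 `Cc1ccc(Cn2cc(COc3ccc4c(=O)ccoc4c3)nn2)cc1`: 10400 nM
Compound 2 `O=c1ccoc2cc(OCc3cn(Cc4ccccc4Br)nn3)ccc12`: > 100000 nM
Compound 3 `O=c1ccoc2cc(OCc3cn(Cc4ccc(Cl)cc4)nn3)ccc12`: > 100000 nM

The value of compound 2 is a limit of the assay, not a number. Compound 3 likewise sits at that limit (the limit of > 100000 nM in this assay, at which 2 of the 3 values shown sit). Compound 2 thus stands at the weak end of what was measured, and its relation to compound 3 is unreadable, since a step that the two limits leave unreadable from compound 2 to compound 3. Compound 4 `COc1ccc(Cn2cc(COc3ccc4c(=O)ccoc4c3)nn2)cc1` is not yet measured; it differs from compound 2 by 4-methoxyphenyl in place of 2-bromophenyl on a saturated chain carbon bound to an aromatic nitrogen. Among the compounds with values here, the one readable step touching compound 2 is an at least 9.6-fold higher number from compound 1 to compound 2 (0.98 log units; beyond the scatter), and the 4-methoxyphenyl of compound 4 resembles the 4-methylphenyl of compound 1 more than the 2-bromophenyl of compound 2. A lower number is therefore expected, estimated as an at least 2.8-fold lower number from compound 2 to compound 4 (0.45 log units; beyond the scatter), with caution because compound 3 also gives > 100000 nM. Compound 4 is estimated at 35000 nM, between 8000 nM and 150000 nM.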

Compound 4, half-maximal inhibitory concentration: 20400 nM
Beside the measured number, compound 4's estimate is 1.7-fold (0.23 log units) above it, and the stated range covers the measured number.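

In this assay the 4-methoxyphenyl gives a readable number, both against the 2-bromophenyl (an at least 4.9-fold lower number from compound 2 to compound 4 (0.69 log units; beyond the scatter)) and against the 4-chlorophenyl (an at least 4.9-fold lower number from compound 3 to compound 4 (0.69 log units; beyond the scatter)). Methoxy and methyl on the aromatic carbon cannot be told apart (a 2.0-fold higher number from compound 1 to compound 4 (0.29 log units; within the scatter)). The first two steps start from limits of the assay, not from numbers: the limit of > 100000 nM in this assay, at which 2 of the 4 values shown sit.

Going by these compounds, only methyl and methoxy give readable numbers here, so how far the trend extends stays open. An amine, a carboxylic acid or a longer ether chain in place of the methoxy could still go either way.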